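The source may hold more compounds than are shown below. What is called first, only, known or untested is meant among the compounds shown, and "the series" means these compounds.

Measured so far:
compound 1, `CC1=CCCC(C)(C)C1/C=C/C(=O)/C=C/c1ccccc1F`: 8300 nM
compound 2, `CC1=CCCC(C)(C)C1/C=C/C(=O)/C=C/c1cc(C(F)(F)F)ccc1F`: 3000 nM
compound 3, `CC1=C(/C=C/C(=O)/C=C/c2cccc(C(F)(F)F)c2)C(C)(C)CCC1O`: 2600 nM

These numbers come from a functional assay on PCa 2b cells (Homo sapiens) for cytotoxicity, read by MTT assay, with a stated time of 72 h; on this read-out lower numbers stand for stronger inhibition and higher numbers for weaker inhibition. Within it, the change from compound 1 to compound 2 is trifluoromethyl in place of hydrogen on an aromatic carbon, and this step gave a 2.8-fold lower number from compound 1 to compound 2 (0.44 log units; beyond the scatter). How the core of compound 3 differs from the core of compound 1 is not broken down here; in this assay compound 3 gives 2600 nM, and compound 2 gives 3000 nM, two values within the scatter of each other.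

Compound 4, `CC1=C(/C=C/C(=O)/C=C/c2cc(C(F)(F)F)cc(C(F)(F)F)c2)C(C)(C)CCC1O`, is still to be tested. It differs from compound 3 by trifluoromethyl in place of hydrogen on an aromatic carbon. This is the same kind of change as from compound 1 to compound 2, but the surroundings differ: in compound 2 the entering group sits para to a fluoro group, in compound 4 it sits meta to a trifluoromethyl group. Because the earlier step gave a 2.8-fold lower number from compound 1 to compound 2 (0.44 log units; beyond the scatter), a somewhat smaller step, a 1.5-fold lower number from compound 3 to compound 4 (0.18 log units; within the scatter), is expected for compound 4, as a group of the same kind is already present on that ring. Compound 4 is therefore estimated at 1700 nM, most likely between 800 nM and 4000 nM.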

Compound 4, half-maximal inhibitory concentration: 3500 nM
Compound 4: middle estimate off by 2.1-fold (0.31 log units), on the low side; low and high end bracket the measured number.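

Swapping hydrogen for trifluoromethyl on an aromatic carbon gave a 1.3-fold higher number from compound 3 to compound 4 (0.13 log units; within the scatter) in this assay, so this second step shows no real change. The drop in the number seen on the first core therefore did not carry over to the second, and the two steps differ by more than ordinary scatter: the same change on two cores in this assay, a 2.8-fold lower number (0.44 log units; beyond the scatter) from compound 1 to compound 2 and a 1.3-fold higher number (0.13 log units; within the scatter) from compound 3 to compound 4, 3.7-fold (0.57 log units) apart, beyond the scatter of two such steps This shows that the size of this change cannot simply be transferred between these two cores, but not why, as both the core and the groups already on the ring differ between the two steps.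

The compounds shown leave open how a different group in this place, such as an amine or a carboxylic acid, would behave on either core. They also leave open what the same change would do on the core of compound 1 with a trifluoromethyl group already on the ring.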